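Cycloalkyl amides on the shared core: compound 2 to compound 3

A few compounds are considered here, and "the series" means these few. Any claim that something is new, unique, unknown or untested is made for them only; others in the source may bear on it.

- compound 1 `CC(C)=CCC/C(C)=C/CC/C(C)=C/CSC[C@H](NC(=O)CCCCCN1CCCC1)C(=O)NC1CCCC1`: 6800 nM
- compound 2 `CC(C)=CCC/C(C)=C/CC/C(C)=C/CSC[C@H](NC(=O)CCCCCN1CCCC1)C(=O)N1CCCCC1`: 8700 nM

In a functional assay on BXPC-3 cells (Homo sapiens) for cytotoxicity, read by fluorescence, with a stated time of 48 h (on this read-out higher numbers stand for an effect only at larger amounts of compound and lower numbers for an effect already at smaller amounts), compound 2 gives 8700 nM, within the scatter of compound 1. Compound 3 `CC(C)=CCC/C(C)=C/CC/C(C)=C/CSC[C@H](NC(=O)CCCCCN1CCCC1)C(=O)NC1CCCCCCC1` carries cyclooctylamino in place of piperidin-1-yl on a carbonyl carbon. Going by the values given here, the only measured step, a 1.3-fold higher number from compound 1 to compound 2 (0.11 log units; within the scatter), is a change at that same carbonyl carbon and stays within the scatter. Among the compounds with values here, no measured compound has an eight-membered ring, so no change beyond the scatter is expected. The estimated step is a 1.3-fold lower number from compound 2 to compound 3 (0.13 log units; within the scatter). For compound 3 the expected value is 6500 nM, with an estimated range of 2800 nM to 13000 nM.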

Compound 3, half-maximal effective concentration: 4000 nM
The estimate for compound 3 lay 1.6-fold (0.21 log units) above the measured number; low and high end bracket the measured number.
By their numbers in this assay, from the lowest: compounds 3, 1 and 2 (each within the scatter of the next, the first and the last beyond it).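

In this assay, going by these compounds alone, the change on the carbonyl carbon now gives a first step beyond the scatter, a 2.2-fold lower number from compound 2 to compound 3 (0.34 log units; beyond the scatter), though the step is modest. With the amide hydrogen kept, cyclooctyl in place of cyclopentyl on the amide-type nitrogen gives only a 1.7-fold lower number from compound 1 to compound 3 (0.23 log units; within the scatter), so ring size alone shows no clear effect between these two amides. No supporting data bear on the reason for either step.

The step from compound 2 to compound 3 changes ring size and the amide hydrogen together, leaving their contributions unseparated. An azocan-1-yl amide would separate them.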